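The source may report more compounds than this note shows. Statements on the series, on what has been measured and on what is new or still open speak of the compounds shown alone.

Measured so far:
- compound 1, `C[C@@H](Cn1ccc(-c2ccc(C#N)c(Cl)c2)n1)NC(=O)c1cccc(OCC(O)CO)c1`: 740 nM
- compound 2, `CC(=O)c1ccc(C(=O)N[C@@H](C)Cn2ccc(-c3ccc(C#N)c(Cl)c3)n2)cc1`: 3600 nM

Working notes on the series. In a functional assay on LNCaP cells (Homo sapiens) for antiproliferative activity, read by CCK-8 assay, with a stated time of 6 days (a lower number here means a stronger inhibitor, a higher number a weaker inhibitor), compound 1 gives 740 nM and compound 2 gives 3600 nM. Compound 2 therefore stands with the highest number of the two, and the gap to compound 1 is beyond the scatter; the two compounds differ in several places, so the gap is noted only as what the two values show.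

Compound 3, `C[C@@H](Cn1ccc(-c2ccc(C#N)c(Cl)c2)n1)NC(=O)C1CC(=O)C1`, is the next compound to be measured in this assay. It differs from compound 2 in one place: 3-oxocyclobutyl in place of 4-acetylphenyl on a carbonyl carbon. Within the data shown here, no measured pair shows this kind of change, so there is no step to lean on. Among the measured compounds shown here, the aromatic ring that leaves is replaced by a much smaller ring, and with no precedent the expected step is small and uncertain in direction, likely within the scatter, a 1.1-fold higher number from compound 2 to compound 3 (0.05 log units; within the scatter). For compound 3 the estimated value in this assay is 4000 nM, expected to fall between 1000 nM and 15000 nM.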

Compound 3, half-maximal inhibitory concentration: 3040 nM
Estimate against measurement, compound 3: 1.3-fold (0.12 log units) above, and the stated range covers the measured number.
By their numbers in this assay, from the lowest: compound 1; then compounds 3 and 2 (each within the scatter of the next).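

In this assay, among these compounds, 3-oxocyclobutyl in place of 4-acetylphenyl on a carbonyl carbon gives a 1.2-fold lower number from compound 2 to compound 3 (0.07 log units; within the scatter) and provides the first one-place pair of the series, in which the two groups do not separate. At this position, the value of compound 2 therefore does not depend on a six-membered aromatic ring of carbon only: a four-membered non-aromatic ring of carbon only, with 5 heavy atoms in place of 9, reads the same within the scatter. No available evidence bears on why the two groups read alike.

The compounds shown leave open whether the ring carbonyl of compound 3 matters, a question that a plain cyclobutyl, or a hydroxyl or an amine on the same ring, would address. Compound 1 differs from compound 3 in more than one place, so the contribution of its 2,3-dihydroxypropoxy chain also remains unresolved.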